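Swapping the amide substituent on a weak compound

A few compounds are considered here, and "the series" means these few. Any claim that something is new, unique, unknown or untested is made for them only; others in the source may bear on it.

Measured so far:
compound 1, `C=CCN(CC=C)C(=O)c1c(C)nc2n1CCC(=O)N2c1c(C)cc(C)cc1C` — > 5000 nM
compound 2, `CCc1nc2n(c1C(=O)N(CC)Cc1ccccc1)CCC(=O)N2c1c(C)cc(C)cc1C` — > 5000 nM

Of the compounds shown here, two sharing one core have been tested in an in vitro assay on IMR-32 cells for displacement of a labelled ligand from corticotropin-releasing factor receptor 1 (Homo sapiens); a higher number here means a weaker inhibitor, a lower number a stronger inhibitor. Compound 1 gives > 5000 nM, which is a limit of the assay rather than a number. Compound 2 gives > 5000 nM, again a limit and not a number. Both values therefore sit at the same limit, as noted in the limit of > 5000 nM in this assay, at which 2 of the 2 values shown sit, and no order between the two compounds can be read from them.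

Compound 3, `C=CCN(CC=C)C(=O)c1c(CC)nc2n1CCC(=O)N2c1c(C)cc(C)cc1C`, is the next compound to be measured in this assay. It differs from compound 2 in one place: diallylamino in place of benzyl(ethyl)amino on a carbonyl carbon. Among the measured compounds shown here, no measured step is available for this change, so its size and direction are not known from the data.

Given that both measured compounds sit at the limit, compound 3 is expected to remain weak, with an estimated inhibition constant of 8000 nM, in the range 3000 nM to 30000 nM. The expected step that the limit leaves unreadable from compound 2 to compound 3 is small and most likely within the scatter.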

Compound 3, inhibition constant: > 5000 nM
Compound 3: a limit, no number (the forecaster's own chance of this, stated with the estimate: 80%); the middle value lies beyond the limit too.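

In this assay compound 3 gives > 5000 nM, which is a limit of the assay and not a number. Among the compounds shown here, no step from compound 1 or compound 2 to compound 3 can be read, as all three compounds sit at one limit: the limit of > 5000 nM in this assay, at which 3 of the 3 values shown sit. From the compounds shown here alone, how far beyond that limit each compound lies, and whether either change alters binding at all, stays open.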